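Aryl Group in Place of Cyclopropyl on the Amide Nitrogen

This account rests on a few compounds, and the source may have more. Where it says the series, first, only, none or still open, it means among the compounds named here.

Measured so far:
compound 1 `O=C1COc2ccc(-c3cccc(NS(=O)(=O)c4ccc(F)cc4)c3)cc2N1C1CC1` — > 40000 nM
compound 2 `COc1ccc(N2C(=O)COc3ccc(-c4ccc(O)cc4)cc32)cc1` — 26100 nM

In a functional assay on HCT-116 cells (Homo sapiens) for antiproliferative activity, read by MTT assay, with a stated time of 72 h (on this read-out higher numbers stand for weaker inhibition and lower numbers for stronger inhibition), compound 1 gives > 40000 nM, which is a limit of the assay rather than a number. Compound 1 thus sits at the limit of > 40000 nM in this assay, at which 1 of the 2 values shown sits. In this assay compound 2 gives 26100 nM. Compound 3 `Cc1ccc(N2C(=O)COc3ccc(-c4cccc(NS(=O)(=O)c5ccc(F)cc5)c4)cc32)cc1` has not yet been measured; it differs from compound 1 by 4-methylphenyl in place of cyclopropyl on an amide-type nitrogen in a ring. Going by the values given here, no measured pair shows this change, so the step of an at least 1.6-fold lower number from compound 1 to compound 3 (0.20 log units; that floor lies within the scatter) is expected to stay within the usual scatter, with compound 3 remaining weak. Compound 3 is estimated at 25000 nM, with a range from 8000 nM to 80000 nM.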

Compound 3, half-maximal inhibitory concentration: 35600 nM
Compound 3: middle estimate off by 1.4-fold (0.15 log units), on the low side, and the stated range covers the measured number.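

In this assay compound 1 gives > 40000 nM as a limit of the assay and not a number. Placing 4-methylphenyl in place of cyclopropyl on the amide-type nitrogen in a ring gives an at least 1.1-fold lower number from compound 1 to compound 3 (0.05 log units; that floor lies within the scatter) and so the step has a floor but no exact size. On this core, swapping the small non-aromatic ring for an aromatic one brings no gain that can be told from the scatter, and inhibition stays weak with both groups. Still open, on these data alone, is whether a carboxylic acid or an amine on that aromatic ring, or a longer chain on this nitrogen, would shift the number.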